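Working notes on a small antiproliferative series

A few compounds are considered here, and "the series" means these few. Any claim that something is new, unique, unknown or untested is made for them only; others in the source may bear on it.

Measured compounds:
compound 1, `O=S(=O)(Nc1cccc2cc[nH]c12)c1ccc(Cl)cc1`, 6 ug/mL
compound 2, `O=S(=O)(Nc1ccc(Cl)c2cc[nH]c12)c1ccc(Cl)cc1`, 9.7 ug/mL
compound 3, `Nc1ccc(S(=O)(=O)Nc2cccc3c(Cl)c[nH]c23)cc1`, 10 ug/mL

In a functional assay on KB cells (Homo sapiens) for antiproliferative activity, read by colorimetric assay and MTT assay (a higher number here means a weaker inhibitor, a lower number a stronger inhibitor), compound 1 gives 6 ug/mL. Compound 2 gives 9.7 ug/mL in this assay, and compound 3 gives 10 ug/mL. All three values lie within the usual scatter of one another, so no order among them is claimed.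

One structural change is seen twice in the series. Between compound 1 and compound 2 it is chloro in place of hydrogen on an aromatic carbon, and the step it made was a 1.6-fold higher number from compound 1 to compound 2 (0.21 log units; within the scatter). The unmeasured compound 4, `Nc1ccc(S(=O)(=O)Nc2ccc(Cl)c3c(Cl)c[nH]c23)cc1`, carries the same change relative to compound 3: chloro in place of hydrogen on an aromatic carbon. The two descriptions of the place are identical word for word, so this is the same change, not merely the same kind. Compound 3 and compound 1 differ in their cores, and that difference is not broken down here; the two values simply stand within the scatter of each other.

Because the earlier step of a 1.6-fold higher number from compound 1 to compound 2 (0.21 log units; within the scatter) was within the scatter, the step from compound 3 to compound 4 in this assay is expected to be small as well, of the order of a 1.3-fold higher number from compound 3 to compound 4 (0.11 log units; within the scatter). Among the measured compounds shown here, this rests only on the single earlier example, so the expectation is held loosely. Compound 4 is estimated at 13 ug/mL, with a likely range from 6 ug/mL to 28 ug/mL.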

Compound 4, half-maximal inhibitory concentration: 14 ug/mL
Estimate against measurement, compound 4: 1.1-fold (0.03 log units) below; low and high end bracket the measured number.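

In this assay the new step is a 1.4-fold higher number from compound 3 to compound 4 (0.15 log units; within the scatter) and it agrees with the earlier one: the same change on two cores in this assay, a 1.6-fold higher number (0.21 log units; within the scatter) from compound 1 to compound 2 and a 1.4-fold higher number (0.15 log units; within the scatter) from compound 3 to compound 4, 1.2-fold (0.06 log units) apart, within the scatter of two such steps.

In these two pairs, then, chloro in place of hydrogen on an aromatic carbon carries from one core to the other with a step of matching size. Both steps lie within the scatter, so the pairs do not show that this change moves the value at all, and two pairs give no rule for any further core in the series.

Chloro is the only group shown entering at this place, so it remains open whether a fluoro, a methyl, a methoxy or a nitrile there would also leave the number within the scatter. Also open, as far as these compounds go, is whether a group that could reveal a larger step, such as a carboxylic acid, an amine or a longer chain, would behave alike on the two cores.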